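The source may report more compounds than this note shows. Statements on the series, on what has been measured and on what is new or still open speak of the compounds shown alone.

Measured compounds: compound 1 `CCc1ccc(-c2nn3cc(-c4cccc(N)c4)nc3s2)cc1` with 22000 nM; compound 2 `C=C(Br)C(=O)Nc1cccc(-c2cn3nc(-c4ccc(F)cc4)sc3n2)c1` with 830 nM; compound 3 `CCOc1ccc(-c2nn3cc(-c4cccc(N)c4)nc3s2)cc1` with > 250000 nM.

In a functional assay on CCRF-CEM cells (Homo sapiens) for inhibition, read by cell counting, with a stated time of 3 days (on this read-out higher numbers stand for weaker inhibition and lower numbers for stronger inhibition), compound 2 gives 830 nM, the lowest of the two numbers shown. Compound 1 gives 22000 nM, a markedly higher number. Compound 3 gives > 250000 nM, which is a limit of this assay rather than a number (the limit of > 250000 nM in this assay, at which 1 of the 3 values shown sits). Within the data shown here, the one measured step, an at least 11-fold higher number from compound 1 to compound 3 (1.05 log units; beyond the scatter), shows that a small change on the phenyl attached to the shared core can move the result a long way.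

Compound 4 `C=C(Br)C(=O)Nc1cccc(-c2cn3nc(Cc4ccccc4)sc3n2)c1` differs from compound 2 by benzyl in place of 4-fluorophenyl on an aromatic carbon. Among the measured compounds shown here, no measured step touches this position directly; the step from compound 1 to compound 3 concerns a substituent on the pendant ring, whereas here the ring itself is exchanged for benzyl. Because an at least 11-fold higher number from compound 1 to compound 3 (1.05 log units; beyond the scatter) was large, a sizeable shift is plausible, and a weakening is the more expected direction. Compound 4 is therefore estimated at 3000 nM, within 800 nM to 12000 nM. The expected step is a 3.6-fold higher number from compound 2 to compound 4 (0.56 log units; beyond the scatter).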

Compound 4, half-maximal inhibitory concentration: 4200 nM
For compound 4 the middle estimate is 1.4-fold (0.15 log units) below the measured one; low and high end bracket the measured number.
By their numbers in this assay, from the lowest: compound 2; then compound 4; then compound 1. At a limit, above all of these: compound 3.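

The exchange of 4-fluorophenyl for benzyl on the aromatic carbon next to the ring sulfur and the ring nitrogen gives, in this assay, a 5.1-fold higher number from compound 2 to compound 4 (0.70 log units; beyond the scatter). The earlier step changed only a substituent on the pendant ring, whereas this one alters how that ring is joined to the shared core and is the first step shown among the compounds carrying the bromoacrylamide group. The result shows that this position responds to the change even though the count of heavy atoms stays the same and a six-membered aromatic ring of carbon only is present on both sides. Nothing measured here gives a reason for this step.

The step changes the fluorine and the linking carbon together, so the compounds shown leave their separate contributions open. Also open, going by these compounds, is how a plain phenyl, a 4-fluorobenzyl or a longer chain such as phenethyl would behave at this position.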